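This account rests on a few compounds, and the source may have more. Where it says the series, first, only, none or still open, it means among the compounds named here.

Measured compounds in a functional assay on P388D1 cells (Mus musculus) for antiproliferative activity, read by MTT assay; a higher number here means a weaker inhibitor, a lower number a stronger inhibitor:
compound 1 `COC(=O)N1CCCc2cc(S(=O)(=O)N3CC(c4ccccc4)NC3=O)ccc21` gives 2260 nM.
compound 3 `NC(=O)N1CCCc2cc(S(=O)(=O)N3CC(c4ccccc4)NC3=O)ccc21` gives 12300 nM.
compound 2 `O=C(CCl)N1CCCc2cc(S(=O)(=O)N3CC(c4ccccc4)NC3=O)ccc21` gives "not determined" (no result reported), so no result for it is on hand in this assay.

Within the data shown here, compound 1 holds the lowest of the two numbers on hand; the only measured step away from it, amino in place of methoxy on the carbonyl carbon, is a 5.4-fold higher number from compound 1 to compound 3 (0.74 log units; beyond the scatter), so the unsubstituted urea of compound 3 stands clearly weaker than the carbamate of compound 1.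

Compound 4 `O=C(NC1CCCCC1)N1CCCc2cc(S(=O)(=O)N3CC(c4ccccc4)NC3=O)ccc21` differs from compound 1 as follows: cyclohexylamino in place of methoxy on a carbonyl carbon. This is the step that bears on it: as in compound 3, a nitrogen takes the place of the methoxy on the carbonyl carbon, but here that nitrogen carries a cyclohexyl group and the change is larger in heavy atoms. Among the measured compounds shown here, only one measured step exists for comparison, and it points toward a higher number when methoxy is replaced by a nitrogen substituent. Whether the cyclohexyl group adds to or offsets that effect cannot be read from the two numbers available, so the expected step is modest, in the direction of a weaker inhibitor, with wide uncertainty.

Compound 4 is therefore expected to give 3500 nM in this assay, within 900 nM to 14000 nM, an estimated step of a 1.5-fold higher number from compound 1 to compound 4 (0.19 log units; within the scatter).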

Compound 4, half-maximal inhibitory concentration: 8160 nM
Compound 4: the middle estimate sits 2.3-fold (0.37 log units) below what was measured; the measured number falls inside the stated range.
By their numbers in this assay, from the lowest: compound 1; then compounds 4 and 3 (each within the scatter of the next).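

In this assay, a second nitrogen-linked group on the carbonyl carbon also gives a higher number than the carbamate of compound 1 (a 3.6-fold higher number from compound 1 to compound 4 (0.56 log units; beyond the scatter)), so the earlier single step from methoxy to amino is no longer alone in its direction. The larger group adds no separation of its own: cyclohexyl in place of hydrogen on the amide-type nitrogen stays within the scatter (a 1.5-fold lower number from compound 3 to compound 4 (0.18 log units; within the scatter)), even though it brings in a six-membered ring of carbon only. Among compounds 1, 3 and 4, the difference therefore follows the exchange of methoxy for a nitrogen-linked group, and neither urea goes against this, while the hydrogen or cyclohexyl on that nitrogen makes no difference beyond the scatter.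

Still open, as far as these compounds go, is whether the carbamate side holds up with an ethoxy group or a longer chain on the oxygen, and whether an anilino group or a dimethylamino group on the carbonyl carbon would fall with the two ureas. No measured evidence accompanies these numbers to explain the steps.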